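Replacing an ethyl group with hydrogen on a dithiocarbamate nitrogen

A few compounds are considered here, and "the series" means these few. Any claim that something is new, unique, unknown or untested is made for them only; others in the source may bear on it.

Of the compounds shown here, two have been measured so far in a functional assay on MCF7 cells (Homo sapiens) for antiproliferative activity, read by MTT assay, with a stated time of 72 h; on this read-out higher numbers stand for weaker inhibition and lower numbers for stronger inhibition. Compound 1 `CCN(CC)C(=S)SCC1=CCOC1=O` gives 121000 nM in this assay. Compound 2 `O=C1CC2(CO1)CSC(=S)N2c1ccccc1` gives 134000 nM in this assay. Compound 1 has the lower of the two numbers, but the gap to compound 2 lies within the scatter of repeated measurements, so the two are not distinguishable on these data.

The step now followed leads from compound 1 to compound 3 `CCNC(=S)SCC1=CCOC1=O`. The change is hydrogen in place of ethyl on an amide-type nitrogen; read one bond further out, it is a diethylamino group becoming an ethylamino group.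

For the measured compounds named here, no step between measured compounds is available to calibrate this change, and both measured compounds sit at the weak end of this assay. A step of modest size in either direction, or none beyond the scatter, is therefore expected from compound 1 to compound 3, as a 1.1-fold higher number from compound 1 to compound 3 (0.03 log units; within the scatter) expresses. Compound 3 is estimated at 130000 nM in this assay, with a range from 50000 nM to 350000 nM.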

Compound 3, half-maximal inhibitory concentration: 80100 nM
Beside the measured number, compound 3's estimate is 1.6-fold (0.21 log units) above it; low and high end bracket the measured number.
By their numbers in this assay, from the lowest: compounds 3, 1 and 2 (each within the scatter of the next).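

In this assay, for the compounds shown here, hydrogen in place of ethyl on the amide-type nitrogen gives a 1.5-fold lower number from compound 1 to compound 3 (0.18 log units; within the scatter), which is the first step between two measured compounds that differ in one place. The earlier compounds shown here could not speak to this position, whereas this pair shows that diethylamino and ethylamino cannot be told apart here: one ethyl group can leave this nitrogen, and a hydrogen can take its place, without the number moving beyond the scatter. No measurement is at hand that would explain the size of this step, and a single pair cannot show whether the same exchange would behave alike on another core.

The compounds shown leave open whether this nitrogen stays as undemanding once the remaining ethyl group also gives way to hydrogen, leaving a primary amino group, or when a longer chain such as butyl or a ring such as piperidine or morpholine is carried there. They also leave open whether a carboxylic acid or an amine at the end of such a chain would move the number beyond the scatter.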